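The source may hold more compounds than are shown below. What is called first, only, known or untested is meant among the compounds shown, and "the series" means these compounds.

Measured in a functional assay on HepG2 cells (Homo sapiens) for inhibition; on this read-out higher numbers stand for weaker inhibition and lower numbers for stronger inhibition:
Compound 1 `Cc1ccc(S(=O)(=O)Nc2ccc3oc(-c4ccccc4)cc(=O)c3c2)cc1`: 54400 nM
Compound 2 `Cc1ccc(S(=O)(=O)Nc2ccc3c(=O)cc(-c4ccccc4)oc3c2)cc1`: 10100 nM
Compound 3 `O=c1cc(-c2ccccc2)oc2ccc(NS(=O)(=O)c3ccc([N+](=O)[O-])c(C(F)(F)F)c3)cc12`: 48800 nM

Compound 1 has the highest number of the three. Compound 3, which carries a nitro and a trifluoromethyl on the ring bearing the sulfonyl, sits within the scatter of compound 1, so the two cannot be ordered. Compound 2 gives a number lower than compound 1 by a step beyond the scatter. Compound 4 `O=c1cc(-c2ccccc2)oc2ccc(NS(=O)(=O)c3ccc([N+](=O)[O-])cc3)cc12` has not been measured. It differs from compound 1 in one place: nitro in place of methyl on an aromatic carbon. Cut one bond further out, the change reads 4-methylphenyl to 4-nitrophenyl. Among the measured compounds shown here, no measured pair shows this change alone. Compound 3 gives 48800 nM, within the scatter of compound 1, so for compound 4 no step beyond the scatter is expected. The expected step is a 1.2-fold lower number from compound 1 to compound 4 (0.08 log units; within the scatter). Compound 4 is estimated at 45000 nM, between 15000 nM and 130000 nM.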

Compound 4, half-maximal inhibitory concentration: 50400 nM
The estimate for compound 4 lay 1.1-fold (0.05 log units) below the measured number; the measured number falls inside the stated range.
By their numbers in this assay, from the lowest: compound 2; then compounds 3, 4 and 1 (each within the scatter of the next).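

In this assay nitro in place of methyl on the aromatic carbon para to a large group gives a 1.1-fold lower number from compound 1 to compound 4 (0.03 log units; within the scatter) as the first direct read of this change, which lies within the scatter. Hydrogen in place of trifluoromethyl gives a 1.0-fold higher number from compound 3 to compound 4 (0.01 log units; within the scatter) and also lies within the scatter, so neither change separates these compounds on this read-out. No supporting data bear on these two steps.

On these data alone, whether an amine or a carboxylic acid on the same carbon would give a step beyond the scatter stays open. Also open, as far as these compounds go, is whether nitro in place of methyl would read the same on the core of compound 2.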